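The source may report more compounds than this note shows. Statements on the series, on what has been measured and on what is new or still open speak of the compounds shown alone.

Compound 1 `CCCOC(=O)c1c(C)coc1-c1ccc2c(CC)cccc2c1OC` gives > 10 ug/mL in a functional assay on A549 cells (Homo sapiens) for cytotoxicity, read by MTT assay, with a stated time of 72 h; a lower number here means that less compound is needed, a higher number that more compound is needed for the effect.
Compound 2 `CCc1cccc2c(OC)c(-c3occ(C)c3C(=O)NC)ccc12` gives > 10 ug/mL in this assay.
Compound 3 `CCc1cccc2c(OC)c(-c3occ(C)c3COC)ccc12` gives > 10 ug/mL in this assay.

Each of these three results is a limit of the assay rather than a number. Compound 3 therefore stands only at a limit in this assay, and the other two compounds stand at the same limit, so that all three sit at the limit of > 10 ug/mL in this assay, at which 3 of the 3 values shown sit. The three measured steps, a step that the two limits leave unreadable from compound 1 to compound 2, a step that the two limits leave unreadable from compound 1 to compound 3 and a step that the two limits leave unreadable from compound 2 to compound 3, are each left unreadable by the two limits at their ends, and none of them shows whether a change on the shared core moves the read-out at all.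

Compound 4 `CCOCc1c(C)coc1-c1ccc2c(CC)cccc2c1OC` differs from compound 3 by methyl in place of hydrogen on a saturated chain carbon bound to an oxygen on a saturated carbon. Within the data shown here, no measured step bears on this change in a readable way, since every step among the three compounds is unreadable. With nothing pointing to a shift in either direction, the expectation for compound 4 in this assay is a step that the limit leaves unreadable from compound 3 to compound 4, none beyond the scatter, and most likely once more a limit. Compound 4 is accordingly estimated at 20 ug/mL, within a range from 8 ug/mL to 60 ug/mL.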

Compound 4, concentration for half-maximal effect: > 10 ug/mL
Compound 4 ended at the assay's limit (the forecaster's own chance of this, stated with the estimate: 80%); the middle value does not contradict the limit.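

In this assay compound 4 gives > 10 ug/mL, which is a limit of the assay. None of the steps to compound 4 from compound 1, compound 2 or compound 3 can be read, and all four compounds stand together: the limit of > 10 ug/mL in this assay, at which 4 of the 4 values shown sit. The compounds shown leave open whether any change on the shared core moves the read-out at all.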